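The source may report more compounds than this note shows. Statements on the series, on what has been measured and on what is new or still open speak of the compounds shown alone.

In a functional assay on IMR-32 cells (Homo sapiens) for antiproliferative activity, read by MTT assay (on this read-out higher numbers stand for weaker inhibition and lower numbers for stronger inhibition), two compounds that share one core have been examined so far. Compound 1 `CC1(C)CCc2c(ccc(C(=O)/C=C/c3ccc(OCc4cn(-c5ccc(Br)cc5)nn4)cc3)c2O)O1` gives 117000 nM in this test, a high number and therefore weak inhibition. Compound 2 `CCc1ccccc1-n1cc(COc2ccc(/C=C/C(=O)c3ccc4c(c3O)CCC(C)(C)O4)cc2)nn1` has no number to stand on: its entry reads "not active" (no number reported) and so it can only be placed as a compound without a measured concentration. Compound 3 `CC1(C)CCc2c(ccc(C(=O)/C=C/c3ccc(OCc4cn(Cc5ccc([N+](=O)[O-])cc5)nn4)cc3)c2O)O1` keeps the shared core and has not yet been measured. The structural change is 4-nitrobenzyl in place of 2-ethylphenyl on an aromatic nitrogen in which 4-nitrobenzyl takes the place of 2-ethylphenyl on an aromatic nitrogen of the five-membered aromatic ring with 3 nitrogen. No size can be counted for this step, since compound 2 offers no figure. The expectation in this assay is a small move toward measurable but still weak inhibition, resting on compound 1 at 117000 nM as the only numerical anchor, and a second result without a number would not be surprising. The expected value for compound 3 is 90000 nM within an estimated range of 30000 nM to 250000 nM in this test.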

Compound 3, half-maximal inhibitory concentration: 17300 nM
Beside the measured number, compound 3's estimate is 5.2-fold (0.72 log units) above it; measured number outside the range, below it.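

The position on the aromatic nitrogen of the five-membered ring responds to the group it carries: in this assay the change to 4-nitrobenzyl in place of 4-bromophenyl gives a 6.8-fold lower number from compound 1 to compound 3 (0.83 log units; beyond the scatter) and so stronger inhibition, a modest step but the first one on this series that can be sized. The step from compound 2 to compound 3 cannot be read, since compound 2 is recorded only as not active, although it does show that a 4-nitrobenzyl group here gives a measurable concentration where a 2-ethylphenyl group gave none. No supporting measurement bears on why the number moved, so the shift stands as an observation only.

Because 4-nitrobenzyl differs from 4-bromophenyl in both its ring substituent and its link to the nitrogen, the compounds shown leave open which of the two accounts for the step, a question that 4-nitrophenyl or 4-bromobenzyl on the same nitrogen would address. They also leave open whether a benzyl group carrying an amine or a carboxylic acid in place of the nitro group would move the number further in either direction.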